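Swapping a Terminal Chain Amine for a Hydroxyl Group

The compounds below may be only part of what the source reports. "The series", "measured", "known", "first", "only" and "open" are said of these compounds alone.

Three compounds share a core carrying a phenol and a long chain attached through an oxygen on the aromatic ring. Compound 1 `NCCCCCCOc1ccc2c(=O)c(-c3ccc(O)cc3)coc2c1` ends that chain in an amino group. In an assay (Cricetulus griseus) for inhibition of Monoamine oxidase (Homo sapiens) (on this read-out higher numbers stand for weaker inhibition and lower numbers for stronger inhibition), compound 1 reaches only a limit of the assay, >> 9000 nM, not a number. Compound 3 `CCCCC(Oc1ccc2c(=O)c(-c3ccc(O)cc3)coc2c1)C(=O)OCC`, whose chain carries an ester branch, likewise gives only a limit in this assay, >> 9000 nM. Compound 2 `O=C(O)CCCCCOc1ccc2c(=O)cc(-c3ccc(O)cc3)oc2c1`, with a carboxylic acid at the chain end, gives a measured value of 7000 nM in this assay. Compound 1 thus stands among the weak inhibitors, as the limit of >> 9000 nM in this assay, at which 2 of the 3 values shown sit, shows.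

Compound 4 `O=c1c(-c2ccc(O)cc2)coc2cc(OCCCCCCO)ccc12` differs from compound 1 in one place: hydroxy in place of amino on a saturated chain carbon, six bonds along the chain from an oxygen on an aromatic ring. Within the data shown here, no pair of measured compounds shows what such a change does, so any expectation rests on the weak values seen so far. The step that the limit leaves unreadable from compound 1 to compound 4 is expected to be small, within the usual scatter, or none at all. Compound 4 is therefore estimated to give about 12000 nM in this assay, somewhere between 3000 nM and 50000 nM, quite possibly again only a limit.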

Compound 4, half-maximal inhibitory concentration: > 9000 nM
Compound 4 gave a limit, no number; the forecaster's own chance of this, stated with the estimate: 60%; the middle value lies beyond the limit too.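

Compound 1 and compound 4 both give only limits in this assay, not numbers, so the size of the step between them cannot be read. Going by these compounds, whether hydroxy in place of amino on this chain changes inhibition at all remains open, as does how much inhibition either compound actually shows.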